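A few compounds are considered here, and "the series" means these few. Any claim that something is new, unique, unknown or untested is made for them only; others in the source may bear on it.

Measured so far:
compound 1 `CC1(C)C=C(n2ccccc2=O)c2cc(C(=O)c3ccc(O)cc3)ccc2O1`: 5.87
compound 2 `CC1(C)C=C(n2ccccc2=O)c2cc(C=C(C#N)C#N)ccc2O1`: 6.3

In a functional assay (trachea) with Rattus norvegicus as the target (a lower number here means a less potent compound, a higher number a more potent compound, by a factor of ten per unit of this negative logarithm), compound 2 stands highest of the two numbers; the nearest is compound 1, and the step of a number 0.43 log units higher from compound 1 to compound 2 (beyond the scatter) lies beyond the scatter. Compound 3 `Cc1ccc(C)n1-c1ccc2c(c1)C(n1ccccc1=O)=CC(C)(C)O2` is not yet measured. It differs from compound 2 by 2,5-dimethyl-1H-pyrrol-1-yl in place of 2,2-dicyanoethenyl on an aromatic carbon. For the measured compounds named here, the only measured step, a number 0.43 log units higher from compound 1 to compound 2 (beyond the scatter), exchanges a different group on an aromatic carbon, so it bears on this change only loosely; no step with the entering group is known. The expected change is a number 0.30 log units lower from compound 2 to compound 3 (within the scatter), likely within or close to the scatter. For compound 3 the estimate in this assay is 6, range 5.4 to 6.6.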

Compound 3, logarithm of the reciprocal of the active concentration, log(1/C): 6.78
Compound 3: middle estimate off by 0.78 log units, on the low side, and the stated range ends below it.
By their numbers in this assay, from the lowest: compound 1; then compound 2; then compound 3.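

In this assay the new group gives two gains on this aromatic carbon: a number 0.48 log units higher from compound 2 to compound 3 (beyond the scatter) and a number 0.91 log units higher from compound 1 to compound 3 (beyond the scatter). For the compounds shown here, this aromatic carbon therefore accepts a directly attached five-membered aromatic ring, with the nitrile and carbonyl groups of the earlier compounds gone, and the three groups now fall in an order set by steps beyond the scatter. Nothing available gives a reason for this order.

On these data alone, what the two methyl groups of the 2,5-dimethyl-1H-pyrrol-1-yl group contribute stays open. So does how an unsubstituted pyrrol-1-yl, an amine or a carboxylic acid on this aromatic carbon would compare.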